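Pyridin-4-yl in place of pyridin-3-yl: compound 3 ahead

A few compounds are considered here, and "the series" means these few. Any claim that something is new, unique, unknown or untested is made for them only; others in the source may bear on it.

In a physicochemical assay for acid dissociation, compound 2 (`O=C(NCc1cccnc1)C1=CCCC1C(=O)N1CCCC1`) gives 4.4 and stands level with compound 1 (`O=C(NCc1ccccn1)C1=CCCC1C(=O)N1CCCC1`) at 4.4 on the digits shown. Compound 3 (`O=C(NCc1ccncc1)C1=CCCC1C(=O)N1CCCC1`) carries pyridin-4-yl in place of pyridin-3-yl on a saturated chain carbon bound to an amide-type nitrogen. For the measured compounds named here, the one measured step bearing on this, pyridin-3-yl in place of pyridin-2-yl at the same place, is no change at the digits printed from compound 1 to compound 2 (within the scatter) and nothing more. No step beyond the scatter is therefore expected in this assay and no firm direction can be given. The estimate means a number 0.10 log units higher from compound 2 to compound 3 (within the scatter) as the expected step. For compound 3 the estimated value is 4.5 with an expected range of 4.2 to 4.8 on this scale.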

Compound 3, acid dissociation constant: 4.4
Compound 3: middle estimate off by 0.10 log units, on the high side; the range from low to high includes it.
By their numbers in this assay, from the lowest: compounds 1, 2 and 3 (each within the scatter of the next).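

In this assay, the change to pyridin-4-yl on a saturated chain carbon bound to an amide-type nitrogen gives no change at the digits printed from compound 2 to compound 3 (within the scatter), and the wider swap gives no change at the digits printed from compound 1 to compound 3 (within the scatter). Pyridin-2-yl, pyridin-3-yl and pyridin-4-yl are therefore interchangeable at this place in this read-out, with compound 1, compound 2 and compound 3 all within the scatter of one another. No supporting data bear on why the values stay level. Still open, from the compounds shown here alone, is whether a phenyl ring, an amine or a carboxylic acid at this place would read differently. Going by these compounds, whether a longer chain in place of the (pyridin-4-yl)methyl group would do so is also open.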